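This account rests on a few compounds, and the source may have more. Where it says the series, first, only, none or still open, it means among the compounds named here.

Of the compounds shown here, two of a shared core have been measured in an assay for inhibition of Amine oxidase [flavin-containing] B (Homo sapiens), read by fluorescence and spectrophotometry, using microsomes, with stated times of 30 min and 20 min; a higher number here means a weaker inhibitor, a lower number a stronger inhibitor. Compound 1 `CC(C)(C)c1ccc(-c2noc(-c3ccc(C4=NCCN4)cc3)n2)cc1` gives 411 nM in this assay. Compound 2 `COc1cccc(-c2noc(-c3ccc(C4=NCCN4)cc3)n2)c1` gives 216 nM in this assay. For the measured compounds named here, the two numbers lie within the usual scatter of each other, so neither compound can be set above the other, and the pair offers no step from which a trend could be read.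

Compound 3 `Cn1ccnc1SCc1ccc(-c2noc(-c3ccc(C4=NCCN4)cc3)n2)cc1` has not yet been measured. It differs from compound 1 by ((1-methyl-1H-imidazol-2-yl)sulfanyl)methyl in place of tert-butyl on an aromatic carbon. Going by the values given here, nothing among the measured compounds shows what such an exchange does in this assay, so the expectation rests only on the range the two measured compounds span. Compound 3 is expected to give about 500 nM in this assay, between 150 nM and 1600 nM. The step from compound 1 to compound 3 is thus estimated at a 1.2-fold higher number from compound 1 to compound 3 (0.09 log units; within the scatter), a step not expected to reach beyond the scatter.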

Compound 3, half-maximal inhibitory concentration: 2280 nM
Estimate against measurement, compound 3: 4.6-fold (0.66 log units) below; measured number above the stated range.
By their numbers in this assay, from the lowest: compounds 2 and 1 (each within the scatter of the next); then compound 3.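

At this position, on an aromatic carbon para to a large group, the exchange of tert-butyl for ((1-methyl-1H-imidazol-2-yl)sulfanyl)methyl gives in this assay a 5.5-fold higher number from compound 1 to compound 3 (0.74 log units; beyond the scatter) and so makes for a weaker inhibitor. For the compounds shown here, this is the first step that lies beyond the scatter, and it shows that the group at this place can move the number, which the earlier pair could not show. Nothing measured here bears on why the number rises.

Going by these compounds alone, the single exchange replaces tert-butyl with a group that brings in sulfur, a methylene link and an imidazole ring together, so which of these parts carries the step stays open. From the compounds shown here alone, whether a simple methyl, a methoxy group or an unlinked imidazole at this place would keep the number of compound 1 also remains unknown.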